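Phenyl for methyl on the ring nitrogen of compound 1

This account rests on a few compounds, and the source may have more. Where it says the series, first, only, none or still open, it means among the compounds named here.

Measured compounds:
compound 1 `Cc1nn(C)c2c1C(c1ccccc1Cl)=NCC(=O)N2` — 16 mg/kg
compound 2 `CCCc1nn(C)c2c1C(c1ccccc1Cl)=NCC(=O)N2` — 250 mg/kg

The study measured two compounds in a functional assay on the whole organism with Rattus norvegicus as the target; on this read-out lower numbers stand for an effect already at smaller amounts and higher numbers for an effect only at larger amounts of compound. Compound 1 `Cc1nn(C)c2c1C(c1ccccc1Cl)=NCC(=O)N2` gives 16 mg/kg, the lowest of the two numbers. Compound 2 `CCCc1nn(C)c2c1C(c1ccccc1Cl)=NCC(=O)N2` gives 250 mg/kg, and the step of a 16-fold higher number from compound 1 to compound 2 (1.19 log units; beyond the scatter) comes from ethyl in place of hydrogen on a saturated chain carbon bound to an aromatic carbon.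

Compound 3 `Cc1nn(-c2ccccc2)c2c1C(c1ccccc1Cl)=NCC(=O)N2` has not been measured. It differs from compound 1 as follows: phenyl in place of methyl on an aromatic nitrogen. Going by the values given here, the change sits on an aromatic nitrogen of the five-membered ring, not on the chain carbon altered in compound 2, so no measured step covers this position directly. Among the compounds with values here, the one step available, a 16-fold higher number from compound 1 to compound 2 (1.19 log units; beyond the scatter), shows that growing a small group on this core by a few carbons moved the number strongly upward. A phenyl entering for methyl is a larger addition still, though at another place, so a higher number is expected for compound 3, probably of smaller size than that step. Compound 3 is therefore estimated at 40 mg/kg, with a range from 10 mg/kg to 160 mg/kg, an expected step of a 2.5-fold higher number from compound 1 to compound 3 (0.40 log units; beyond the scatter).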

Compound 3, minimum effective dose: 500 mg/kg
Compound 3: the middle estimate sits 13-fold (1.10 log units) below what was measured; the measured number lies above the stated range.
By their numbers in this assay, from the lowest: compound 1; then compounds 2 and 3 (each within the scatter of the next).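

In this assay, going by these compounds alone, phenyl in place of methyl on an aromatic nitrogen gives a 31-fold higher number from compound 1 to compound 3 (1.49 log units; beyond the scatter) and so makes clear that the group on this nitrogen matters strongly, which the earlier compounds could not show. Within the data shown here, the only earlier step, a 16-fold higher number from compound 1 to compound 2 (1.19 log units; beyond the scatter) on the chain carbon, concerned another place, so two separate places on the shared core now respond, and in both steps the number rises as the entering group brings more heavy atoms than the group it replaces. Compound 1, with its methyl on the nitrogen and its methyl on the ring carbon, keeps the lowest number of the three, and nothing in hand explains the rise at this nitrogen.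

The compounds shown leave open whether the rise belongs to the aromatic ring of phenyl or would also come with ethyl or a longer chain on this nitrogen. They also leave open what hydrogen in place of methyl would do there, and whether a phenyl carrying an amine or a carboxylic acid would keep the number as high.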